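The source may report more compounds than this note shows. Statements on the series, on what has been measured and on what is new or still open speak of the compounds shown alone.

Measured so far, in a functional assay on cells (Cancer cell lines, Homo sapiens) for inhibition; a lower number here means a stronger inhibitor of growth, a higher number a weaker inhibitor of growth:

Compound 1, `N=C(N)N/N=C/c1c(-c2cccs2)nc2sccn12`, gives 12900 nM.
Compound 2, `Cc1cc(-c2nc3sccn3c2/C=N/NC(=N)N)c(C)s1`, gives 16600 nM.
Compound 3, `Cc1cc(-c2nc3n(c2/C=N/NC(=N)N)CCS3)c(C)s1`, gives 17000 nM.

All three carry the same amidinohydrazone side chain on a fused two-ring core and differ in the aromatic ring attached to that core, or in the core itself. Compound 2 and compound 1 differ in one place only, the change being (thiophen-2-yl in place of 2,5-dimethylthiophen-3-yl on an aromatic carbon). In this assay that step gave a 1.3-fold lower number from compound 2 to compound 1 (0.11 log units; within the scatter), so the two numbers sit within the usual scatter of one another and show no real separation.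

Compound 3 and compound 2 carry the same 2,5-dimethylthiophen-3-yl ring but on different cores; the difference between the two cores is not broken down here. Their numbers in this assay are also within the scatter of each other.

Compound 4, `N=C(N)N/N=C/c1c(-c2cccs2)nc2n1CCS2`, is not yet measured. It stands to compound 3 as compound 1 stands to compound 2: the change is thiophen-2-yl in place of 2,5-dimethylthiophen-3-yl on an aromatic carbon. The surroundings of the place are not identical, since in compound 3 the changed carbon is also two ring bonds from two ring atoms that each bear a fused ring, so this is the same kind of change rather than the same change. Because the earlier step gave a 1.3-fold lower number from compound 2 to compound 1 (0.11 log units; within the scatter), a step of about a 1.3-fold lower number from compound 3 to compound 4 (0.10 log units; within the scatter) is expected here, and compound 4 is estimated at 13500 nM, with a likely range from 7000 nM to 27000 nM.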

Compound 4, concentration for 50% growth inhibition: 28800 nM
For compound 4 the middle estimate is 2.1-fold (0.33 log units) below the measured one; the whole stated range lies below it.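

In this assay, putting thiophen-2-yl in place of 2,5-dimethylthiophen-3-yl on the second core gave a 1.7-fold higher number from compound 3 to compound 4 (0.23 log units; within the scatter), so this step on its own shows no real separation. Set beside the same change on the other core, this step does not differ from the earlier one by more than repeated measurements would allow: the same change on two cores in this assay, a 1.3-fold lower number (0.11 log units; within the scatter) from compound 2 to compound 1 and a 1.7-fold higher number (0.23 log units; within the scatter) from compound 3 to compound 4, 2.2-fold (0.34 log units) apart, within the scatter of two such steps. The four numbers therefore fit a change that has no clear effect on either core, and the two steps should not be read as pointing in different ways, but they do not prove that the change behaves identically on both cores, as a modest difference between the cores could stay hidden in steps this small.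

The compounds shown leave open whether a different group at this place, such as a phenyl group or a ring carrying an amine or a carboxylic acid, would move the number in this assay beyond the scatter on either core. They also leave open how that number would respond to a change in the amidinohydrazone side chain, such as a longer chain linking it to the core.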